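A few compounds are considered here, and "the series" means these few. Any claim that something is new, unique, unknown or untested is made for them only; others in the source may bear on it.

Measured in a functional assay on MCF7 cells (Homo sapiens) for antiproliferative activity, read by MTT assay, with a stated time of 24 h; a lower number here means a stronger inhibitor, a higher number a weaker inhibitor:
compound 1 `O=S(=O)(c1ccccc1)n1c(-c2cn(-c3ccccc3)nc2-c2ccc(F)cc2)nc2ccccc21` gives 690 nM
compound 2 `COc1ccc(S(=O)(=O)n2c(-c3cn(-c4ccccc4)nc3-c3ccc(F)cc3)nc3ccccc32)cc1` gives 530 nM
compound 3 `O=[N+]([O-])c1ccc(S(=O)(=O)n2c(-c3cn(-c4ccccc4)nc3-c3ccc(F)cc3)nc3ccccc32)cc1` gives 1370 nM

These three compounds differ in one place only. Compound 3 does not separate cleanly from both neighbours. The data show a 2.6-fold higher number from compound 2 to compound 3 (0.41 log units; beyond the scatter) as a modest but real difference, whereas a 2.0-fold higher number from compound 1 to compound 3 (0.30 log units; within the scatter) stays inside the normal noise of the measurement.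

The next compound is compound 4 `O=S(=O)(c1ccc(F)cc1)n1c(-c2cn(-c3ccccc3)nc2-c2ccc(F)cc2)nc2ccccc21` and its change from compound 3 is fluoro in place of nitro on an aromatic carbon in words, fluoro in place of nitro on an aromatic carbon, para to a large group.

Going by the values given here, no fluoro compound has been measured, so the evidence is indirect. Hydrogen and methoxy at this place cannot be told apart, since a 1.3-fold lower number from compound 1 to compound 2 (0.11 log units; within the scatter) lies within the scatter. Only nitro stands apart, and only from methoxy. If fluoro behaves like hydrogen or methoxy rather than nitro, which is an assumption, compound 4 should land near compound 1 and compound 2. The expected change is a 2.0-fold lower number from compound 3 to compound 4 (0.29 log units; within the scatter) and it is a small estimated move toward a stronger inhibitor. In this assay compound 4 is estimated at 700 nM with 350 nM to 1400 nM as its expected range.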

Compound 4, half-maximal inhibitory concentration: 3670 nM
The estimate for compound 4 lay 5.2-fold (0.72 log units) below the measured number; the whole stated range lies below it.
By their numbers in this assay, from the lowest: compounds 2, 1 and 3 (each within the scatter of the next, the first and the last beyond it); then compound 4.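

In this assay, this position proves more sensitive than the first three compounds suggested, since fluoro separates clearly from hydrogen, with a 5.3-fold higher number from compound 1 to compound 4 (0.73 log units; beyond the scatter), and from methoxy, with a 6.9-fold higher number from compound 2 to compound 4 (0.84 log units; beyond the scatter). Nitro had been the only group to stand apart, and only from methoxy, yet fluoro goes further in the same direction, with a 2.7-fold higher number from compound 3 to compound 4 (0.43 log units; beyond the scatter), which makes compound 4 the weakest inhibitor of the four. Size, counted in heavy atoms, does not set the order here: fluoro has one heavy atom and nitro has three, so a group need not be large to raise the number at this place, on a six-membered aromatic ring of carbon only, para to a large group.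

No measurement among these compounds accounts for why fluoro stands apart from the other three groups. From the compounds shown here alone, it remains open whether this result is particular to fluoro or is shared by other groups at the same place, and chloro, bromo, a methyl group or an amine on this ring would help to tell those two readings apart.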